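Quinolinyl for Indolyl on a Triazole-Linked Arylpiperazine

A few compounds are considered here, and "the series" means these few. Any claim that something is new, unique, unknown or untested is made for them only; others in the source may bear on it.

Compound 1 `Clc1cccc(N2CCN(CCCCn3cc(-c4ccc5ncccc5c4)nn3)CC2)c1Cl`: > 1000 nM
Compound 2 `COc1ccccc1N1CCN(CCCCn2cc(-c3ccc4[nH]ccc4c3)nn2)CC1`: 222 nM

In an assay on HEK293 cells for displacement of a labelled ligand from D(4) dopamine receptor (Homo sapiens), read by scintillation counting, with a stated time of 1 h (a lower number here means a stronger inhibitor, a higher number a weaker inhibitor), compound 1 reaches only a limit of the assay, not a number: the limit of > 1000 nM in this assay, at which 1 of the 2 values shown sits. Going by the values given here, compound 2 gives 222 nM in this assay, the only number among the values shown. Compound 3 `COc1ccccc1N1CCN(CCCCn2cc(-c3ccc4ncccc4c3)nn2)CC1` differs from compound 2 in one place: quinolin-6-yl in place of 1H-indol-5-yl on an aromatic carbon. Among the compounds with values here, no measured pair isolates this change, so its size is uncertain. The step of a 2.7-fold higher number from compound 2 to compound 3 (0.43 log units; beyond the scatter) is expected to be a loss somewhat beyond the scatter. Compound 3 is estimated at 600 nM in this assay, with a range from 200 nM to 2000 nM.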

Compound 3, inhibition constant: 269 nM
Beside the measured number, compound 3's estimate is 2.2-fold (0.35 log units) above it; the measured number falls inside the stated range.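

In this assay, quinolin-6-yl and 1H-indol-5-yl are not told apart at this aromatic carbon: a 1.2-fold higher number from compound 2 to compound 3 (0.08 log units; within the scatter), even though the hydrogen-bond donor leaves and a hydrogen-bond acceptor enters. With quinolin-6-yl held in place, 2-methoxyphenyl in place of 2,3-dichlorophenyl on the ring amine nitrogen gives an at least 3.7-fold lower number from compound 1 to compound 3 (0.57 log units; beyond the scatter), so quinolin-6-yl by itself does not set compound 1 apart. Compound 1 remains a limit of the assay, not a number: the limit of > 1000 nM in this assay, at which 1 of the 3 values shown sits.

The compounds shown leave open whether a naphthyl group at this carbon, with no ring nitrogen, would fit with compound 2 and compound 3. They also leave open whether a longer chain would keep this match.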